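Changing the Aryl Group on the Sulfonyl Sulfur

A few compounds are considered here, and "the series" means these few. Any claim that something is new, unique, unknown or untested is made for them only; others in the source may bear on it.

compound 1 `CN1CCN(c2ccc3[nH]nc(S(=O)(=O)c4ccccc4Cl)c3c2)CC1`: 4 nM
compound 2 `CN1CCN(c2cccc3c(S(=O)(=O)c4cccc5ccccc45)n[nH]c23)CC1`: 4.6 nM

Of the compounds shown here, two have been measured in an assay on HeLa cells for displacement of a labelled ligand from 5-hydroxytryptamine receptor 6 (Homo sapiens); a lower number here means a stronger inhibitor, a higher number a weaker inhibitor. Compound 1 gives 4 nM, the lowest of the two numbers. Compound 2 gives 4.6 nM in this assay; the gap to compound 1 lies within the scatter, so the two cannot be ranked.

Compound 3 `COc1cccc(S(=O)(=O)c2n[nH]c3ccc(N4CCN(C)CC4)cc23)c1` has not yet been measured. It differs from compound 1 in one place: 3-methoxyphenyl in place of 2-chlorophenyl on a sulfonyl sulfur. For the measured compounds named here, no measured pair shows the effect of this change, so the expectation rests only on the two values above and on the change itself. Both measured aryl groups on the sulfonyl sulfur give strong inhibition, so the shared core is expected to tolerate the swap with at most a modest weakening; the step of a 2.0-fold higher number from compound 1 to compound 3 (0.30 log units; within the scatter) is the expected size. The estimate for compound 3 in this assay is 8 nM, with a range from 2 nM to 40 nM.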

Compound 3, inhibition constant: 1.1 nM
The estimate for compound 3 lay 7.3-fold (0.86 log units) above the measured number; the measured number lies below the stated range.
By their numbers in this assay, from the lowest: compound 3; then compounds 1 and 2 (each within the scatter of the next).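

In this assay, the aryl group on a sulfonyl sulfur turns out to do more than keep strong inhibition in place: 3-methoxyphenyl in place of 2-chlorophenyl gives a 3.6-fold lower number from compound 1 to compound 3 (0.56 log units; beyond the scatter). The step is modest but beyond the scatter, so with the rest of the molecule unchanged, the choice of aryl group at this position does move the number. Nothing at hand accounts for the shift.

As far as these compounds go, this single pair cannot separate the departure of the chlorine from the arrival of the methoxy group, and how an unsubstituted phenyl group on the sulfonyl sulfur would compare remains open. From the compounds shown here alone, it also remains open whether the number stays this low with an amine or a carboxylic acid on that aryl ring in place of the methoxy group.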